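This account rests on a few compounds, and the source may have more. Where it says the series, first, only, none or still open, it means among the compounds named here.

Compound 1, `CCCCNc1nc(N)nc2c1CN(C(=O)c1ccccc1)CC2`, gives 1.4 uM in an assay on HEK293 cells for agonist activity at Toll-like receptor 8 (Homo sapiens), read by a luciferase reporter, with a stated time of 6 h; on this read-out lower numbers stand for an effect already at smaller amounts and higher numbers for an effect only at larger amounts of compound.
Compound 2, `CCCCNc1nc(N)nc2c1CN(Cc1cccnc1)CC2`, gives 0.13 uM.
Compound 3, `CCCCNc1nc(N)nc2c1CN(C(=O)c1cscn1)CC2`, gives 0.5 uM.

Among these three numbers, compound 3 holds the second highest; its nearest neighbour is compound 1, separated by a 2.8-fold lower number from compound 1 to compound 3 (0.45 log units; beyond the scatter), and its furthest is compound 2, separated by a 3.8-fold higher number from compound 2 to compound 3 (0.59 log units; beyond the scatter). The largest movement in the set, an 11-fold lower number from compound 1 to compound 2 (1.03 log units; beyond the scatter), comes from exchanging the whole group on the ring nitrogen.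

Compound 4, `CCCCNc1nc(N)nc2c1CN(C(=O)c1csc(N)n1)CC2`, keeps the (1,3-thiazol-4-yl)carbonyl of compound 3 and differs from it only in one place: amino in place of hydrogen on an aromatic carbon.

Within the data shown here, none of the measured steps adds a small group onto an aromatic ring that is otherwise kept. The steps from compound 1 to compound 3 and from compound 2 to compound 3 concern the whole group on the ring nitrogen and so bear on this change only loosely, showing that alterations in that region of the shared core move the read-out by modest amounts. Among the measured compounds shown here, with no direct precedent, the expected step is a 1.3-fold lower number from compound 3 to compound 4 (0.10 log units; within the scatter), most likely not beyond the scatter in either direction. Compound 4 is therefore estimated at 0.4 uM, within a range from 0.15 uM to 1.2 uM in this assay.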

Compound 4, minimum effective concentration: 6.9 uM
Compound 4: the middle estimate sits 17-fold (1.24 log units) below what was measured; measured number above the stated range.
By their numbers in this assay, from the lowest: compound 2; then compound 3; then compound 1; then compound 4.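

In this assay, the position on the aromatic carbon next to the ring nitrogen and next to the ring sulfur proves highly sensitive: amino in place of hydrogen, a change of a single heavy atom, gives a 14-fold higher number from compound 3 to compound 4 (1.14 log units; beyond the scatter), a large step on the same scale as the exchange of the whole group on the ring nitrogen in an 11-fold lower number from compound 1 to compound 2 (1.03 log units; beyond the scatter). The modest advantage of 1,3-thiazol-4-yl over phenyl does not survive this change, for 2-amino-1,3-thiazol-4-yl in place of phenyl gives a 4.9-fold higher number from compound 1 to compound 4 (0.69 log units; beyond the scatter), and exchanging the (pyridin-3-yl)methyl for the (2-amino-1,3-thiazol-4-yl)carbonyl gives a 53-fold higher number from compound 2 to compound 4 (1.72 log units; beyond the scatter), the widest gap in the set. Nothing available here offers an explanation for the size of this step.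

The compounds shown leave open whether the step belongs to the amino group itself or would also follow a methyl, a methylamino or an acetylamino group on the same carbon. They also leave open whether amino would act the same way on the phenyl of compound 1, or on a thiazole joined to the ring nitrogen through a methylene instead of a carbonyl.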